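Cyclising the urea tail of a vasopressin receptor agonist

A few compounds are considered here, and "the series" means these few. Any claim that something is new, unique, unknown or untested is made for them only; others in the source may bear on it.

Two compounds share one core and differ in the group hanging from the urea. Compound 1 `CCc1cc(C(=O)N2CCCCc3ccccc32)ccc1CNC(=O)Nc1c(F)cccc1F` carries a difluorophenyl group there and, in a functional assay on HEK293 cells for agonist activity at Vasopressin V2 receptor (Homo sapiens), read by a luciferase reporter and cAMP accumulation (a lower number here means that less compound is needed, a higher number that more compound is needed for the effect), compound 1 gives 10 nM. Compound 2 `Cc1cc(C(=O)N2CCCCc3ccccc32)ccc1CNC(=O)NCC(=O)N(C)C` carries a small open chain ending in a dimethylamide; in this assay compound 2 gives 58 nM, the higher of the two numbers, and the gap to compound 1 lies beyond the usual scatter. Compound 3 `Cc1cc(C(=O)N2CCCCc3ccccc32)ccc1CNC(=O)N1C[C@H](O)C[C@H]1C(=O)N(C)C` is the same as compound 2 except for one change: 2-(dimethylcarbamoyl)-4-hydroxypyrrolidin-1-yl in place of ((dimethylcarbamoyl)methyl)amino on a carbonyl carbon. The open chain is thus folded into a ring bearing a hydroxyl group. For the measured compounds named here, no measured pair shows what such a change does here, so the expected step of a 1.5-fold lower number from compound 2 to compound 3 (0.16 log units; within the scatter) is a modest one, most likely not beyond the scatter and, if anything, toward a lower number. Compound 3 is estimated at 40 nM, with a plausible range from 10 nM to 160 nM.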

Compound 3, half-maximal effective concentration: 2.3 nM
The estimate for compound 3 lay 17-fold (1.24 log units) above the measured number, and the stated range ends above it.
By their numbers in this assay, from the lowest: compound 3; then compound 1; then compound 2.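

In this assay, putting 2-(dimethylcarbamoyl)-4-hydroxypyrrolidin-1-yl in place of ((dimethylcarbamoyl)methyl)amino on the carbonyl carbon gives a 25-fold lower number from compound 2 to compound 3 (1.40 log units; beyond the scatter) and so marks a large step, well beyond the scatter. This place in the molecule is therefore far from indifferent: it responds strongly to a change that keeps the dimethylcarbamoyl group but adds a five-membered ring, a hydroxyl group and two defined stereocentres. No measurement here explains why the step is so large.

These features arrive together. The compounds shown cannot divide the step between the ring and the hydroxyl group; a plain pyrrolidine ring without the hydroxyl group would separate them. They also leave open whether the opposite arrangement at the stereocentres, or a carboxylic acid in place of the dimethylamide, would keep the number this low.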